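Bromo for chloro in a two-compound series

The source may hold more compounds than are shown below. What is called first, only, known or untested is meant among the compounds shown, and "the series" means these compounds.

compound 1 `O=C(Nc1ccc(OC(F)(F)F)c(Cl)c1)c1cc(F)ccc1O` gives 700 nM
compound 2 `O=C(Nc1ccc(Cl)c(Cl)c1)c1cc(F)ccc1O` gives 670 nM

Both values come from a functional assay on Jurkat cells (Homo sapiens) for cytotoxicity, read by luminescence and CellTiter-Glo, with a stated time of 3 days; on this read-out lower numbers stand for stronger inhibition and higher numbers for weaker inhibition. Among the compounds with values here, they lie within the scatter of each other, so compound 2 stands level with compound 1 among the only two numbers known. The unmeasured compound 3 `O=C(Nc1ccc(Br)c(Cl)c1)c1cc(F)ccc1O` differs from compound 2 in one place: bromo in place of chloro on an aromatic carbon. Within the data shown here, one measured step bears on this, on the same aromatic carbon: chloro in place of trifluoromethoxy gave a 1.0-fold lower number from compound 1 to compound 2 (0.02 log units; within the scatter) in this assay and so stayed within the scatter. A single step is thin evidence, and it favours neither direction. The estimated step is a 1.0-fold lower number from compound 2 to compound 3 (0.01 log units; within the scatter) and none beyond the scatter is expected. In this assay compound 3 is estimated at 650 nM (expected range 320 nM to 1300 nM).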

Compound 3, half-maximal inhibitory concentration: 860 nM
Compound 3: middle estimate off by 1.3-fold (0.12 log units), on the low side; low and high end bracket the measured number.
By their numbers in this assay, from the lowest: compounds 2, 1 and 3 (each within the scatter of the next).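

In this assay, the aromatic carbon ortho to a chloro group and para to a large group has now carried three different groups: chloro, trifluoromethoxy and bromo. Bromo in place of chloro gives a 1.3-fold higher number from compound 2 to compound 3 (0.11 log units; within the scatter), and bromo in place of trifluoromethoxy gives a 1.2-fold higher number from compound 1 to compound 3 (0.09 log units; within the scatter), so with the earlier step, all three pairs lie within the scatter and this cell read-out does not separate these groups at this position. Nothing available explains why the three compounds read alike.

As far as these compounds go, it remains open whether a different kind of group here, such as an amine, a carboxylic acid or a longer chain, would shift the number beyond the scatter. The compounds shown also leave open how changes elsewhere on the shared core would read.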